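The source may hold more compounds than are shown below. What is called first, only, known or untested is meant among the compounds shown, and "the series" means these compounds.

Compound 1 `O=C(CCCCCCC(=O)Nc1ccc(C(F)(F)F)cc1)NO`: 530 nM
Compound 2 `O=C(CCCCCCC(=O)Nc1ccc(Cl)cc1)NO`: 770 nM

In a functional assay on Jurkat cells (Homo sapiens) for antiproliferative activity, with a stated time of 48 h (on this read-out lower numbers stand for an effect already at smaller amounts and higher numbers for an effect only at larger amounts of compound), compound 2 gives 770 nM, which lies within the usual scatter of compound 1 at 530 nM. These two compounds are the only ones measured so far. Compound 3 `O=C(CCCCCCC(=O)Nc1ccc(I)cc1)NO` is still unmeasured and carries iodo in place of chloro on an aromatic carbon. Among the measured compounds shown here, one measured step bears on this change, the exchange of trifluoromethyl for chloro at that ring carbon, which is a 1.5-fold higher number from compound 1 to compound 2 (0.16 log units; within the scatter). For the measured compounds named here, that step stayed within the scatter, but no measured compound yet carries iodo, so the evidence is thin. No step beyond the scatter is therefore expected in this assay, and no direction can be favoured. The expected step is a 1.2-fold lower number from compound 2 to compound 3 (0.07 log units; within the scatter). Compound 3 is estimated at 650 nM, with an expected range from 300 nM to 1400 nM.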

Compound 3, half-maximal effective concentration: 240 nM
Beside the measured number, compound 3's estimate is 2.7-fold (0.43 log units) above it; measured number outside the range, below it.
By their numbers in this assay, from the lowest: compound 3; then compounds 1 and 2 (each within the scatter of the next).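

In this assay, iodo in place of chloro on this aromatic carbon gives a 3.2-fold lower number from compound 2 to compound 3 (0.51 log units; beyond the scatter), a modest step but the first at this position to lie beyond the scatter. Iodo in place of trifluoromethyl gives a 2.2-fold lower number from compound 1 to compound 3 (0.34 log units; beyond the scatter), also modest and beyond the scatter, so the position does respond to the group it carries, which the exchange of trifluoromethyl for chloro alone did not show. No measurement at hand offers a reason for this difference.

As far as these compounds go, it remains open whether bromo, a nitrile or a methoxy group at this carbon would go with iodo or stay within the scatter of chloro and trifluoromethyl. From the compounds shown here alone, it is also open whether the gain from iodo would persist with a longer chain in place of the present one.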